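Hydroxy on the Sulfonyl Chain: Expected Maximal Response

The source may hold more compounds than are shown below. What is called first, only, known or untested is meant among the compounds shown, and "the series" means these compounds.

Compound 1, `CCCc1cnc(N2CCC(C3Cc4cc(C5=CCN(S(=O)(=O)CCC)CC5)ccc4O3)CC2)nc1`, gives 107% in a functional assay on HEK293 cells with Glucose-dependent insulinotropic receptor (Homo sapiens) as the target, read by cAMP accumulation, with a stated time of 60 min; a higher number here means a larger maximal response, a lower number a smaller maximal response.
Compound 2, `CCCc1cnc(N2CCC(C3(C)Cc4cc(C5=CCN(S(=O)(=O)CCC)CC5)ccc4O3)CC2)nc1`, gives 48% in this assay.

Within the data shown here, compound 2 holds the lower of the two numbers in this assay; the one step measured, a number 59 percentage points lower from compound 1 to compound 2 (beyond the scatter), lies beyond the scatter and separates it from compound 1. Compound 3, `CCCc1cnc(N2CCC(C3(C)Cc4cc(C5=CCN(S(=O)(=O)CCCO)CC5)ccc4O3)CC2)nc1`, is not yet measured. It differs from compound 2 by hydroxy in place of hydrogen on a saturated chain carbon, three bonds along the chain from a sulfonyl sulfur. Among the measured compounds shown here, no measured step touches this chain: the single known step concerns a saturated ring carbon, so it offers no direct guide to the present change. With nothing to point either way, the expectation in this assay is a step of a number 2 percentage points higher from compound 2 to compound 3 (within the scatter), that is, nothing beyond the scatter, though the uncertainty is wide. Compound 3 is therefore estimated at about 50% in this assay. Its range is expected to run from 30% to 75%.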

Compound 3, largest response reached (Emax), in percent of the reference or control that the assay uses: 78%
Compound 3: the middle estimate sits 28 percentage points below what was measured; the measured number lies above the stated range.
By their numbers in this assay, from the lowest: compound 2; then compound 3; then compound 1.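

The place on a saturated chain carbon, three bonds along the chain from a sulfonyl sulfur, is not a silent one: in this assay the change from propyl to 3-hydroxypropyl gives a number 30 percentage points higher from compound 2 to compound 3 (beyond the scatter) and so moves the maximal response upward. Among these compounds, until now the only measured change was on a saturated ring carbon, where methyl in place of hydrogen gave a number 59 percentage points lower from compound 1 to compound 2 (beyond the scatter); this step shows that the sulfonyl chain can also shift the response, and in the opposite direction. Nothing available explains how the hydroxy produces this rise.

Going by these compounds, it remains open whether the rise is specific to hydroxy or would also appear with a methoxy, an amine or a carboxylic acid at this place. Among the compounds shown here, the change is seen only on compound 2, so its size on compound 1, which has hydrogen on the saturated ring carbon, is also unknown.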